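The source may hold more compounds than are shown below. What is called first, only, known or untested is meant among the compounds shown, and "the series" means these compounds.

Three compounds sharing one core were measured in an ADME assay on MCF-10A cells (Homo sapiens) for cytotoxicity, read by MTT assay, with a stated time of 24 h; on this read-out higher numbers stand for weaker inhibition and lower numbers for stronger inhibition. Compound 1, `FC(F)(F)C(F)(F)C(F)(F)C(F)(F)C(F)(F)C(F)(F)CCn1cc(COc2ccccc2-c2nc3ccccc3s2)nn1`, gives 35100 nM. Compound 2, `COc1ccc(-c2cc(COc3ccccc3-c3nc4ccccc4s3)on2)cc1`, gives 34100 nM. Compound 3, `COc1cc(-c2cc(COc3ccccc3-c3nc4ccccc4s3)on2)cc(OC)c1OC`, gives 42900 nM. All three numbers lie within the usual scatter of one another, so compound 2 stands at no separate place among them. Compound 4, `Clc1ccc(-c2cc(COc3ccccc3-c3nc4ccccc4s3)on2)cc1`, differs from compound 2 in one place: chloro in place of methoxy on an aromatic carbon. With the three measured compounds so close together, the step from compound 2 to compound 4 is expected to stay within the scatter, in no clear direction, as a 1.0-fold higher number from compound 2 to compound 4 (0.01 log units; within the scatter). In this assay compound 4 is therefore estimated at 35000 nM, with a range from 17000 nM to 70000 nM.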

Compound 4, half-maximal inhibitory concentration: 38800 nM
Beside the measured number, compound 4's estimate is 1.1-fold (0.04 log units) below it; low and high end bracket the measured number.
By their numbers in this assay, from the lowest: compounds 2, 1, 4 and 3 (each within the scatter of the next).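

In this assay, for the compounds shown here, the exchange of 4-methoxyphenyl for 4-chlorophenyl gives a 1.1-fold higher number from compound 2 to compound 4 (0.06 log units; within the scatter) and is the first single change that can be read. At this place, on an aromatic carbon para to a large group, chloro and methoxy therefore cannot be told apart in this assay, although they differ in heavy atoms and hydrogen-bond acceptors. No measurement offered here accounts for this result. From the compounds shown here alone, whether an amine or a carboxylic acid at this place would give a number beyond the scatter remains open.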